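Compound 2 to compound 4: allyl in place of hydrogen

The source may report more compounds than this note shows. Statements on the series, on what has been measured and on what is new or still open speak of the compounds shown alone.

In a functional assay on WiDr cells (Homo sapiens) for antiproliferative activity, read by sulforhodamine B assay, with a stated time of 48 h (a lower number here means a stronger inhibitor of growth, a higher number a weaker inhibitor of growth), compound 1 (`CC(C)(C)[Si](C)(C)O[C@H]1CCCO[C@@H]1CO`) reads > 100000 nM, which is a limit of the assay and not a number. Compound 2 (`CC(C)(C)[Si](C)(C)O[C@@H]1CCCO[C@@H]1CO`) reads > 100000 nM, also a limit. Within the data shown here, compound 3 (`CC(C)(C)[Si](C)(C)O[C@H]1CCCO[C@@H]1COCC(=O)OCc1ccccc1`) gives 28000 nM, the only actual number so far.

The next change leads to compound 4 (`C=CCOC[C@H]1OCCC[C@H]1O[Si](C)(C)C(C)(C)C`) and is allyl in place of hydrogen on an oxygen on a saturated carbon, turning hydroxymethyl to (allyloxy)methyl. Among the measured compounds shown here, the one measured step is a step that the two limits leave unreadable from compound 1 to compound 2. As far as these compounds go, it concerns (the fact that compounds 1 and 2 differ only in the configuration as drawn), and its size stays unknown, given (the limit of > 100000 nM in this assay, at which 2 of the 3 values shown sit). For the measured compounds named here, no measured step therefore sizes this change.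

Going by the values given here, compound 3 at 28000 nM shows only that a number can be reached in this assay, so a modest move towards stronger growth inhibition is expected. For compound 4 a real chance of another limit remains. The estimated step is an at least 1.6-fold lower number from compound 2 to compound 4 (0.22 log units; that floor lies within the scatter), with its size poorly defined. For compound 4 the expected value is 60000 nM, with an estimated range of 20000 nM to 100000 nM.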

Compound 4, concentration for 50% growth inhibition: 88000 nM
Beside the measured number, compound 4's estimate is 1.5-fold (0.17 log units) below it, within the range that was stated.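

Allyl in place of hydrogen on this oxygen gives a readable number in this assay: compound 4 gives 88000 nM. Compound 2 stands at > 100000 nM, which is a limit of the assay and not a number. The change therefore reads as an at least 1.1-fold lower number from compound 2 to compound 4 (0.05 log units; that floor lies within the scatter), and only this floor can be stated because one end of the step is a limit: the limit of > 100000 nM in this assay, at which 2 of the 4 values shown sit.

The compounds shown leave open how a propyl chain, a primary amine or a carboxylic acid would read in this assay when carried on this oxygen in place of allyl. Also open, as far as these compounds go, is whether the configuration at the saturated ring carbon matters for the (allyloxy)methyl series, as the step from compound 1 to compound 2 cannot be read.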